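This account rests on a few compounds, and the source may have more. Where it says the series, first, only, none or still open, it means among the compounds named here.

The series shares one core, seen in compound 1 `COc1cccc(CNCc2c(C(=O)O)n(Cc3ccc(C)cc3)c3cc(C)ccc23)c1`, compound 2 `COc1cccc(CNCc2c(C(=O)O)n(Cc3ccc(O)cc3)c3ccccc23)c1` and compound 3 `COc1cccc(CNCc2c(C(=O)O)n(Cc3ccc(F)cc3)c3ccccc23)c1`, which differ in the group on the benzyl ring and, for compound 1, in an extra methyl on the core. In a functional assay on Bel-7402 cells (Homo sapiens) for antiproliferative activity, read by MTT assay, with a stated time of 72 h (on this read-out higher numbers stand for weaker inhibition and lower numbers for stronger inhibition), compound 1 gives 5670 nM. Compound 2 reaches only a limit of this assay, > 50000 nM. Compound 3 likewise stands at a limit, > 50000 nM, so its place on the numbers is known only as that limit. The step that the two limits leave unreadable from compound 2 to compound 3 cannot be sized because of the limit of > 50000 nM in this assay, at which 2 of the 3 values shown sit. Compound 4 `COc1cccc(CNCc2c(C(=O)O)n(Cc3ccc(C)cc3)c3ccccc23)c1` carries the change (methyl in place of fluoro on an aromatic carbon). No measured step bears directly on this change: the one step shown is unreadable, and compound 1 differs from compound 4 in a second place, so only its value can be noted. Since compound 1, which also carries the methylbenzyl, gives 5670 nM, compound 4 is expected to fall somewhat weaker than that value, with the step of an at least 3.3-fold lower number from compound 3 to compound 4 (0.52 log units; beyond the scatter) expected to run toward stronger inhibition but of uncertain size. Compound 4 is therefore estimated at 15000 nM, within a range from 4000 nM to 50000 nM.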

Compound 4, half-maximal inhibitory concentration: 21500 nM
Compound 4: middle estimate off by 1.4-fold (0.16 log units), on the low side; the range from low to high includes it.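

With the 4-methylbenzyl group, the series comes off the limit in this assay: methyl in place of fluoro gives an at least 2.3-fold lower number from compound 3 to compound 4 (0.36 log units; beyond the scatter), and methyl in place of hydroxy gives an at least 2.3-fold lower number from compound 2 to compound 4 (0.36 log units; beyond the scatter), so this place on the benzyl ring responds to the change, though both steps are only lower bounds on its size. The new value also isolates the extra methyl on the core of compound 1: hydrogen in place of that methyl gives a 3.8-fold higher number from compound 1 to compound 4 (0.58 log units; beyond the scatter), so the 4-methylbenzyl group alone does not account for the value of compound 1. The step from compound 2 to compound 3 still cannot be read, and neither can the true size of the steps to compound 4: the limit of > 50000 nM in this assay, at which 2 of the 4 values shown sit.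

On these data alone, it remains open whether an ethyl, a methoxy or a chloro group at this place on the benzyl ring would match or pass methyl. Also open, as far as these compounds go, is whether the methyl on the core would bring the fluoro and hydroxy compounds onto the numbers as well, or whether its step depends on the methyl on the benzyl ring.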